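The source may hold more compounds than are shown below. What is called first, only, known or untested is meant among the compounds shown, and "the series" means these compounds.

Notes on the series. The shared core is carried by compound 1 `COCCNC(=O)[C@H]1CC[C@@H](Nc2ncc3c(Br)nn(-c4ccc5ncccc5c4)c3n2)C1` and compound 2 `COCCNC(=O)[C@@H]1CC[C@@H](Nc2ncc3c(Br)nn(-c4ccc5ncccc5c4)c3n2)C1`, which have the same atoms and bonds and differ only in configuration as drawn. In an assay on isolated protein for inhibition of eIF-2-alpha kinase GCN2 (Homo sapiens) (on this read-out higher numbers stand for weaker inhibition and lower numbers for stronger inhibition), compound 1 gives 61 nM; in this assay compound 2 gives 5 nM. Within the data shown here, the only measured step, a 12-fold lower number from compound 1 to compound 2 (1.09 log units; beyond the scatter), rests on (the fact that compounds 1 and 2 differ only in the configuration as drawn). Of the two numbers shown, compound 2 stands at the lower one.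

Compound 3 `CNC(=O)[C@@H]1CC[C@@H](Nc2ncc3c(Br)nn(-c4ccc5ncccc5c4)c3n2)C1` is still to be measured. Relative to compound 2 the change is hydrogen in place of methoxymethyl on a saturated chain carbon bound to an amide-type nitrogen, with the configuration unchanged. Among the measured compounds shown here, no measured step touches the amide substituent; the one measured step concerns configuration only and gives no guide to the size or direction of this change. In this assay no step beyond the scatter is therefore expected. Compound 3 is expected to give 7 nM in this assay, within 2 nM to 25 nM, meaning an expected step of a 1.4-fold higher number from compound 2 to compound 3 (0.15 log units; within the scatter).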

Compound 3, half-maximal inhibitory concentration: 21 nM
Estimate against measurement, compound 3: 3.0-fold (0.48 log units) below, and the stated range covers the measured number.
By their numbers in this assay, from the lowest: compound 2; then compound 3; then compound 1.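

In this assay, the amide substituent turns out to be a position that responds to change: going from (2-methoxyethyl)carbamoyl to methylcarbamoyl, with the configuration unchanged, gives a 4.2-fold higher number from compound 2 to compound 3 (0.62 log units; beyond the scatter). The earlier compounds shown here showed only that configuration matters, whereas this step shows that the methoxymethyl part of the chain also counts, and in the direction of stronger inhibition when it is present. Nothing at hand accounts for this step, since the only available note concerns configuration.

Going by these compounds, it remains open whether the step follows from the chain length or from its oxygen, which a butyl chain or a 2-hydroxyethyl group would help to separate, and how a 2-aminoethyl group or a carboxylic acid at the chain end would read. Also open, on these data alone, is whether the same change gives a similar step in the configuration of compound 1.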